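A few compounds are considered here, and "the series" means these few. Any claim that something is new, unique, unknown or untested is made for them only; others in the source may bear on it.

Compound 1 `COc1cccc(/C=C/C(=O)c2ccc(OC)c3c2OC(C)(C)C=C3)c1`: > 10000 nM
Compound 2 `COc1ccc(C(=O)/C=C/c2cccc(Cl)c2)c2c1C=CC(C)(C)O2`: > 10000 nM

Both were tested in a functional assay on HT-29 cells (Homo sapiens) for antiproliferative activity, read by MTT assay, with a stated time of 24 h; a lower number here means a stronger inhibitor, a higher number a weaker inhibitor. The value of compound 1 in this assay, > 10000 nM, is a limit of the assay rather than a number. The value of compound 2 in this assay, > 10000 nM, is likewise a limit. The step that the two limits leave unreadable from compound 1 to compound 2 is therefore unreadable, and compound 2 stands at the limit of > 10000 nM in this assay, at which 2 of the 2 values shown sit. Compound 3 `COc1ccc(C(=O)/C=C/c2ccc(Cl)c(Cl)c2)c2c1C=CC(C)(C)O2` differs from compound 2 by chloro in place of hydrogen on an aromatic carbon, reading as 3-chlorophenyl to 3,4-dichlorophenyl. Going by the values given here, no measured step bears on this change. The expected step that the limit leaves unreadable from compound 2 to compound 3 is small. Compound 3 is estimated at 15000 nM, with a range from 4000 nM to 60000 nM.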

Compound 3, half-maximal inhibitory concentration: 7580 nM
The estimate for compound 3 lay 2.0-fold (0.30 log units) above the measured number; the range from low to high includes it.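

In this assay, going by these compounds alone, a chloro group on the aromatic carbon ortho to a chloro group and para to a large group gives the first readable number here, with an at least 1.3-fold lower number from compound 2 to compound 3 (0.12 log units; that floor lies within the scatter). Putting 3,4-dichlorophenyl in place of 3-methoxyphenyl gives an at least 1.3-fold lower number from compound 1 to compound 3 (0.12 log units; that floor lies within the scatter). The change thus takes compound 3 off the limit that the other two share, though the floor of the step stays within the scatter: the limit of > 10000 nM in this assay, at which 2 of the 3 values shown sit.

Going by these compounds, the true size of both steps stays open, for the values of compound 1 and compound 2 are limits. Also open, on these data alone, is whether an amine or a carboxylic acid at this position would give a lower number than chloro.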